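The source may report more compounds than this note shows. Statements on the series, on what has been measured and on what is new or still open speak of the compounds shown alone.

In a functional assay on NCI-H460 cells (Homo sapiens) for cytotoxicity, read by sulforhodamine B assay, with a stated time of 3 days (on this read-out lower numbers stand for stronger inhibition and higher numbers for weaker inhibition), the measured compounds stand as follows:
compound 1 `OCc1cn(Cc2cccc(Cl)c2)c2ccccc12` gives 19 nM
compound 2 `OCc1cn(Cc2cccc(I)c2)c2ccccc12` gives 100 nM
compound 3 `OCc1cn(Cc2cccc(C(F)(F)F)c2)c2ccccc12` gives 39 nM

Compound 3 at 39 nM holds the middle place among the three numbers. Two steps mark its distance from its neighbours: a 2.1-fold higher number from compound 1 to compound 3 (0.31 log units; beyond the scatter) on the nearer side and a 2.6-fold lower number from compound 2 to compound 3 (0.41 log units; beyond the scatter) on the further side.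

The next structure is compound 4 `Cc1cccc(Cn2cc(CO)c3ccccc32)c1` with methyl in place of trifluoromethyl on an aromatic carbon, meta to a large group (methyl in place of trifluoromethyl on an aromatic carbon). Among the measured compounds shown here, no measured compound carries methyl, so the evidence is indirect. For the measured compounds named here, the only guide is the set of swaps among chloro, iodo and trifluoromethyl at this same place. The widest of these is a 5.3-fold higher number from compound 1 to compound 2 (0.72 log units; beyond the scatter) and all three are modest. They fix no direction for methyl. In this assay the likeliest outcome is therefore no step beyond the scatter, with a modest step in either direction still possible. The expected step is a 1.1-fold lower number from compound 3 to compound 4 (0.05 log units; within the scatter) on this estimate. For compound 4 the estimated value is 35 nM with an expected range from 14 nM to 90 nM on the same reasoning.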

Compound 4, half-maximal inhibitory concentration: 31 nM
Compound 4: middle estimate off by 1.1-fold (0.05 log units), on the high side; the range from low to high includes it.
By their numbers in this assay, from the lowest: compounds 1, 4 and 3 (each within the scatter of the next, the first and the last beyond it); then compound 2.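

In this assay, methyl at this place on the aromatic ring gives a 1.3-fold lower number from compound 3 to compound 4 (0.10 log units; within the scatter), so among the compounds shown, replacing trifluoromethyl with this smaller group, which carries no halogen, leaves the number within the scatter. The comparison with chloro gives a 1.6-fold higher number from compound 1 to compound 4 (0.21 log units; within the scatter), also within the scatter, although the chloro and trifluoromethyl compounds lie beyond the scatter of each other, while the comparison with iodo gives a 3.2-fold lower number from compound 2 to compound 4 (0.51 log units; beyond the scatter), so the iodo compound now stands apart from all three other compounds by steps beyond the scatter. No measurement is available here that would account for these steps.

As far as these compounds go, what a hydroxyl, a methoxy, an amine or a carboxylic acid would give at this same place remains open, as does a longer chain such as ethyl or propyl. Also open, from the compounds shown here alone, is whether the order seen among chloro, methyl, trifluoromethyl and iodo would hold at other places on this ring, or with the hydroxymethyl group of the shared core replaced.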